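Methyl to Ethyl on the Ring Nitrogen: Expected Tolerance

A few compounds are considered here, and "the series" means these few. Any claim that something is new, unique, unknown or untested is made for them only; others in the source may bear on it.

Compound 1: `CCn1ncc2ccc(N/C(C)=C3\C(=O)C=C(C)OC3=O)cc21`, > 100000 nM
Compound 2: `CC1=CC(=O)/C(=C(/C)Nc2ccc3c(Cl)nn(C)c3c2)C(=O)O1`, > 100000 nM

In an ADME assay on RAW264.7 cells (Mus musculus) for cytotoxicity, read by resazurin assay, with a stated time of 48 h (a higher number here means that more compound is tolerated, a lower number that less compound is tolerated), compound 2 reaches only a limit of the assay, > 100000 nM, so no number is known for it. The same holds for compound 1, which also gives a limit, > 100000 nM. Both measured compounds therefore sit at the top of what this assay can report, as noted in the limit of > 100000 nM in this assay, at which 2 of the 2 values shown sit.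

Compound 3, `CCn1nc(Cl)c2ccc(N/C(C)=C3\C(=O)C=C(C)OC3=O)cc21`, differs from compound 2 by methyl in place of hydrogen on a saturated chain carbon bound to an aromatic nitrogen; seen one bond further out, this is methyl to ethyl. Among the compounds with values here, no measured pair shows this change, so no step size is known. Compound 1 already carries the ethyl and is tolerated up to the limit, so no change beyond the usual scatter is expected for the step that the limit leaves unreadable from compound 2 to compound 3. Compound 3 is accordingly expected to reach 150000 nM, with a range from 60000 nM to 400000 nM, most likely again reported as a limit.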

Compound 3, half-maximal cytotoxic concentration: 6230 nM
Beside the measured number, compound 3's estimate is 24-fold (1.38 log units) above it; measured number below the stated range.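

In this assay, methyl in place of hydrogen on a saturated chain carbon bound to an aromatic nitrogen gives an at least 16-fold lower number from compound 2 to compound 3 (1.20 log units; beyond the scatter), so this one-carbon change is not neutral when the chloro group is present. Chloro in place of hydrogen on an aromatic carbon, with the ethyl already there, gives an at least 16-fold lower number from compound 1 to compound 3 (1.20 log units; beyond the scatter). Among these three compounds, ethyl without chloro and chloro without ethyl both stay at a limit, and only their combination gives a measured number.

As far as these compounds go, how large either step really is stays unknown, because each starting compound gives only a limit: the limit of > 100000 nM in this assay, at which 2 of the 3 values shown sit. Whether a longer chain at the same place, or bromo or a nitrile in place of the chloro, would also lower the tolerated concentration remains open.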